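The source may hold more compounds than are shown below. What is called first, only, known or untested is meant among the compounds shown, and "the series" means these compounds.

Compound 2 `CCC(CC)C1C(C(=O)c2ccc(OC)cc2)=C(O)C(=O)N1c1ccc(-c2ccon2)cc1` gives the higher of the two half-lives recorded in an ADME assay on the whole organism (Rattus norvegicus) for metabolic stability (on this read-out higher numbers stand for a longer-lived compound and lower numbers for a shorter-lived compound), namely 4.2 h. Compound 1 `O=C(C1=C(O)C(=O)N(c2ccc(-c3ccon3)cc2)C1C1CCCCC1)c1ccc(CO)cc1` stands at 1.4 h in this assay, a gap from compound 2 that lies beyond the usual scatter. Within the data shown here, no single-change step between measured compounds exists, so what follows rests on the structural change alone.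

Compound 3 `COc1ccc(C(=O)C2=C(O)C(=O)N(c3ccc(-c4ccon4)cc3)C2c2ccccc2OCCO)cc1` differs from compound 2 in one place: 2-(2-hydroxyethoxy)phenyl in place of pentan-3-yl on a saturated ring carbon. Nothing measured here isolates this change. Among the measured compounds shown here, because compound 1, the only other measured compound, carries a hydroxy-bearing group and gives 1.4 h, a shift toward shorter half-life is expected, though of modest size. For compound 3 the estimated step from compound 2 is a 1.8-fold lower number from compound 2 to compound 3 (0.24 log units; within the scatter). Compound 3 is expected to give about 2.4 h in this assay, within a range from 0.8 h to 7 h.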

Compound 3, half-life: 0.5 h
Estimate against measurement, compound 3: 4.8-fold (0.68 log units) above; the whole stated range lies above it.
By their numbers in this assay, from the lowest: compound 3; then compound 1; then compound 2.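

Swapping pentan-3-yl for 2-(2-hydroxyethoxy)phenyl on the saturated ring carbon next to the ring nitrogen gives an 8.4-fold lower number from compound 2 to compound 3 (0.92 log units; beyond the scatter) in this assay and is the first comparison here in which only one place changes. It shows that this position alone can move the half-life by more than the usual scatter, a point that compounds 1 and 2 could not settle, as they differ in more than one place. Nothing available explains why the half-life falls with this change.

The entering group brings a six-membered aromatic ring and a hydroxy-bearing chain together, so the compounds shown cannot separate the two parts. A plain phenyl or a 2-methoxyphenyl group at this position would show whether the ring or the terminal hydroxy group goes with the shorter half-life.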